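This account rests on a few compounds, and the source may have more. Where it says the series, first, only, none or still open, it means among the compounds named here.

In a functional assay on M14 cells (Homo sapiens) for cytotoxicity (on this read-out higher numbers stand for weaker inhibition of growth and lower numbers for stronger inhibition of growth), compound 1 `COc1ccc(C2=C(c3ccc(SC)cc3)CC3CCCN3C2=O)cc1C` gives 200 nM, while compound 2 `CSc1ccc(C2=C(c3ccc(Br)cc3)C(=O)N3CCCC3C2)cc1` gives 9000 nM, the higher of the two numbers. Compound 3 `CSc1ccc(C2=C(c3ccc(SC)cc3)C(=O)N3CCCC3C2)cc1` differs from compound 2 by one change: methylsulfanyl in place of bromo on an aromatic carbon. For the measured compounds named here, the only measured step bearing on this place is a 45-fold higher number from compound 1 to compound 2 (1.65 log units; beyond the scatter), which is large and beyond the scatter. Going by the values given here, no measured compound carries methylsulfanyl at this place, so the direction is uncertain. A moderate fall is expected, with an estimated step of a 3.6-fold lower number from compound 2 to compound 3 (0.56 log units; beyond the scatter). For compound 3 the expected value is 2500 nM, with an estimated range of 500 nM to 10000 nM.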

Compound 3, concentration for 50% growth inhibition: 5000 nM
Compound 3: middle estimate off by 2.0-fold (0.30 log units), on the low side; low and high end bracket the measured number.
By their numbers in this assay, from the lowest: compound 1; then compounds 3 and 2 (each within the scatter of the next).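

In this assay, methylsulfanyl in place of bromo on the aromatic carbon gives a 1.8-fold lower number from compound 2 to compound 3 (0.26 log units; within the scatter) and so leaves the two groups indistinguishable at this place. Compound 1 now stands apart from a second partner, since 4-(methylsulfanyl)phenyl in place of 4-methoxy-3-methylphenyl gives a 25-fold higher number from compound 1 to compound 3 (1.40 log units; beyond the scatter) and repeats the large step seen with 4-bromophenyl. No measurement given here explains these numbers. The compounds shown leave open how an amine, a carboxylic acid or a longer chain would read at this place, and whether methoxy alone or methyl alone on that ring accounts for the value of compound 1.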